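The source may report more compounds than this note shows. Statements on the series, on what has been measured and on what is new or still open speak of the compounds shown alone.

Measured so far in a functional assay on the whole organism (aorta) with Rattus norvegicus as the target; a higher number here means a larger maximal response, a lower number a smaller maximal response:
- compound 1, `O=[N+]([O-])c1ccc2c(c1)C(c1cccc[n+]1[O-])=CC(CF)(CF)O2`: 66.3%
- compound 2, `N#C[N-][n+]1ccccc1C1=CC(CF)(CF)Oc2ccc(C(F)(F)C(F)(F)F)cc21`: 71.9%

On the numbers shown, compound 2 and compound 1 lie within the scatter of each other, so the two results cannot be told apart, and nothing about the direction of any change can be read from this pair. For the measured compounds named here, no step between compounds differing in one place has been measured in this assay.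

Compound 3, `N#C[N-][n+]1ccccc1C1=CC(CF)(CF)Oc2ccc(C(F)(F)C(F)(F)C(F)(F)F)cc21`, differs from compound 2 in one place: trifluoromethyl in place of fluoro on a saturated chain carbon bound to two fluorine atoms and a saturated chain carbon. The shared core of compound 2 and compound 3 is otherwise unchanged. Going by the values given here, with no measured step of this kind available, the expectation for the step from compound 2 to compound 3 in this assay is that it stays within the scatter, with no direction favoured: a number 1.9 percentage points lower from compound 2 to compound 3 (within the scatter). Compound 3 is therefore estimated at 70% in this assay, expected to fall between 55% and 85%.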

Compound 3, intrinsic activity: the largest response reached, in percent of the reference agonist's: 74.6%
For compound 3 the middle estimate is 4.6 percentage points below the measured one; low and high end bracket the measured number.
By their numbers in this assay, from the lowest: compounds 1, 2 and 3 (each within the scatter of the next).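

In this assay, trifluoromethyl in place of fluoro on a saturated chain carbon bound to two fluorine atoms and a saturated chain carbon gives a number 2.7 percentage points higher from compound 2 to compound 3 (within the scatter), the first one-place step read in this series. At this position, therefore, 1,1,2,2,2-pentafluoroethyl and 1,1,2,2,3,3,3-heptafluoropropyl cannot be told apart by maximal response, and the step gives no direction for this change. Nothing available bears on why the two results stand so close.

As far as these compounds go, it remains open whether a longer perfluorinated chain, such as nonafluorobutyl, would also stay within the scatter of compound 3. Also open, from the compounds shown here alone, is how a plain propyl chain, an amine or a carboxylic acid in place of the fluorinated chain would compare with compound 2 on the same shared core.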